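From carboxy to ethoxycarbonyl: what one small change may do

The source may report more compounds than this note shows. Statements on the series, on what has been measured and on what is new or still open speak of the compounds shown alone.

compound 1 (`CCOC(=O)/C=C/c1ccc(OC)c(OC(=O)c2nc(C)c(C)nc2C)c1`) gives 29900 nM as its value
compound 2 (`Cc1nc(C)c(C(=O)Oc2cccc(/C=C/C(=O)O)c2)nc1C`) gives 24000 nM as its value

Both numbers come from a functional assay on EA.hy 926 cells (Homo sapiens) for cytotoxicity, read by MTT assay, with stated times of 24 h and 12 h (a higher number here means that more compound is needed for the effect, a lower number that less compound is needed), and lie within the usual scatter of each other, so compound 2 cannot be ranked against compound 1. These two values are all that is known so far.

Compound 3 (`CCOC(=O)/C=C/c1cccc(OC(=O)c2nc(C)c(C)nc2C)c1`) differs from compound 2 in one place (ethyl in place of hydrogen on an oxygen next to a carbonyl group), with ethyl in place of hydrogen on an oxygen next to a carbonyl group, which turns carboxy into ethoxycarbonyl. Among the measured compounds shown here, no measured pair shows this change on its own, so its size in this assay cannot be read directly from the data. The 2-(ethoxycarbonyl)ethenyl group does occur in compound 1 (29900 nM), a value within the scatter of that of compound 2 (24000 nM), so no step beyond the scatter is expected, in either direction. The expected change is a 1.1-fold higher number from compound 2 to compound 3 (0.03 log units; within the scatter) and remains only an estimate. The estimated value for compound 3 is 26000 nM with an expected range from 11000 nM to 60000 nM for now.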

Compound 3, half-maximal effective concentration: 92600 nM
Estimate against measurement, compound 3: 3.6-fold (0.55 log units) below; the measured number lies above the stated range.
By their numbers in this assay, from the lowest: compounds 2 and 1 (each within the scatter of the next); then compound 3.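

In this assay the carboxy group of compound 2 proves not to be interchangeable with ethoxycarbonyl: ethyl in place of hydrogen on that oxygen gives a 3.9-fold higher number from compound 2 to compound 3 (0.59 log units; beyond the scatter) and so more compound is needed for the effect. Compound 1 gave no hint of such a step, but it also carries a methoxy group, and hydrogen in place of that methoxy on an aromatic carbon gives a 3.1-fold higher number from compound 1 to compound 3 (0.49 log units; beyond the scatter) as a second modest rise. The two ethoxycarbonyl compounds are therefore not alike, and the closeness of the first two numbers does not show that the change from carboxy to ethoxycarbonyl is silent in this assay. No measurement at hand says why either step occurs.

As far as these compounds go, whether the rise belongs to ethyl itself or to any group placed on that oxygen stays open, since a methyl ester, a longer chain or an amide in place of the ester could each be set on the same scale. Also open, from the compounds shown here alone, is the size of the carboxy to ethoxycarbonyl change when the methoxy group is present, which only a compound carrying both carboxy and methoxy could show.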